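Aryl Swap on the Shared Core: From Bromine to Chlorine

The compounds below may be only part of what the source reports. "The series", "measured", "known", "first", "only" and "open" are said of these compounds alone.

Measured so far:
- compound 1 `O=C1/C(=C\c2ccc(O)cc2)c2ccccc2N1c1c(Cl)cccc1Cl`: 30 ug/mL
- compound 2 `O=C1/C(=C\c2cccc(Br)c2)c2ccccc2N1c1c(Cl)cccc1Cl`: 19 ug/mL

In a functional assay on L132 cells (Homo sapiens) for cytotoxicity, read by MTT assay, with a stated time of 72 h (on this read-out higher numbers stand for an effect only at larger amounts of compound and lower numbers for an effect already at smaller amounts), compound 2 gives 19 ug/mL, the lowest of the two numbers shown; the nearest is compound 1 with 30 ug/mL, and the step of a 1.6-fold lower number from compound 1 to compound 2 (0.20 log units; within the scatter) lies within the scatter, so the two are not separated. Compound 3 `O=C1/C(=C\c2ccccc2Cl)c2ccccc2N1c1c(Cl)cccc1Cl` is not yet measured in this assay. It differs from compound 2 in one place: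

2-chlorophenyl in place of 3-bromophenyl on a double-bonded chain carbon bound to a double-bonded ring carbon

Going by the values given here, the only measured step that bears on this change is the aryl exchange at the same position, a 1.6-fold lower number from compound 1 to compound 2 (0.20 log units; within the scatter), which stayed within the scatter. From this alone no step beyond the scatter is expected for compound 3 in this assay, in either direction. Compound 3 is therefore estimated at 20 ug/mL, with a range from 8 ug/mL to 50 ug/mL; the expected step is a 1.1-fold higher number from compound 2 to compound 3 (0.02 log units; within the scatter).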

Compound 3, concentration for half-maximal effect: > 100 ug/mL
Compound 3 gave a limit, no number; the forecaster's own chance of this, stated with the estimate: 5%; middle value at least 5.0-fold (0.69 log units) from the limit.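

At this place, on a double-bonded chain carbon bound to a double-bonded ring carbon, the aryl group can separate compounds, which compound 1 and compound 2 had not shown. In this assay, 2-chlorophenyl in place of 3-bromophenyl gives an at least 5.2-fold higher number from compound 2 to compound 3 (0.72 log units; beyond the scatter), and 2-chlorophenyl in place of 4-hydroxyphenyl gives an at least 3.3-fold higher number from compound 1 to compound 3 (0.52 log units; beyond the scatter). The reading for compound 3 is a limit and not a number, so the true size of both steps stays unknown: the limit of > 100 ug/mL in this assay, at which 1 of the 3 values shown sits.

Compound 3 differs from compound 2 in both the halogen and where it sits on the phenyl ring, so the step does not show which of the two matters; 2-bromophenyl and 3-chlorophenyl would separate them. From the compounds shown here alone, how an amine or a carboxylic acid on the phenyl ring would read also remains open.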